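The compounds below may be only part of what the source reports. "The series", "measured", "known", "first", "only" and "open" are said of these compounds alone.

Three compounds share one core and differ only in the group attached to the carbonyl carbon of the amide. Compound 1 `O=C(Nc1ccc(Cl)c(-c2nnc3c(Cl)cccn23)c1)c1ccccn1` carries a pyridin-2-yl group there. In a functional assay on AN3-CA cells (Homo sapiens) for antiproliferative activity, read by MTT assay, with a stated time of 72 h (on this read-out lower numbers stand for stronger inhibition and higher numbers for weaker inhibition), compound 1 gives > 100000 nM, which is a limit of the assay rather than a number. Compound 2 `Cc1cc(Cl)ccc1C(=O)Nc1ccc(Cl)c(-c2nnc3c(Cl)cccn23)c1` carries a 4-chloro-2-methylphenyl group, and in this assay compound 2 gives > 100000 nM, again a limit. Compound 3 `O=C(Nc1ccc(Cl)c(-c2nnc3c(Cl)cccn23)c1)c1ccon1` carries a 1,2-oxazol-3-yl group, and in this assay compound 3 gives > 100000 nM, also a limit. The steps between them, a step that the two limits leave unreadable from compound 1 to compound 2, a step that the two limits leave unreadable from compound 1 to compound 3 and a step that the two limits leave unreadable from compound 2 to compound 3, therefore have no readable size. Compound 3 thus stands at the same limit as the two others, as the evidence the limit of > 100000 nM in this assay, at which 3 of the 3 values shown sit, sums up.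

Compound 4 `O=C(Nc1ccc(Cl)c(-c2nnc3c(Cl)cccn23)c1)c1ccccc1Cl` changes compound 3 by 2-chlorophenyl in place of 1,2-oxazol-3-yl on a carbonyl carbon. Going by the values given here, none of the measured steps gives a readable size that could guide this change, and because the limit of > 100000 nM in this assay, at which 3 of the 3 values shown sit, places every value at the limit, compound 4 is expected to stay at the limit too. The estimated step from the change is a number no higher from compound 3 to compound 4 (the limit leaves the size open). In this assay compound 4 is expected to give about 100000 nM, within a range from 30000 nM to 300000 nM.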

Compound 4, half-maximal inhibitory concentration: > 100000 nM
Compound 4: a limit, no number (the forecaster's own chance of this, stated with the estimate: 80%); the middle value sits exactly at the limit.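

In this assay compound 4 gives > 100000 nM as a limit and not a number. Its steps from compound 1, compound 2 and compound 3 therefore cannot be read: the limit of > 100000 nM in this assay, at which 4 of the 4 values shown sit. The compounds shown leave open how strongly any of them acts, and whether changing the group on the carbonyl carbon alters that at all.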